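Aryl variation at the saturated ring carbon

The compounds below may be only part of what the source reports. "The series", "measured", "known", "first", "only" and "open" are said of these compounds alone.

Measured so far in an assay on Sf9 cells for inhibition of serine/threonine-protein kinase 4 (Homo sapiens), read by luminescence and ADP-Glo, with a stated time of 1 h, in the presence of a further agent that is not named here; a higher number here means a weaker inhibitor, a lower number a stronger inhibitor:
- compound 1 `CCC1C(=O)N(C)c2cnc(Nc3ccc(S(N)(=O)=O)cc3)nc2N1C`: compound 1 gives 479 nM
- compound 2 `CN1C(=O)C(c2cccc(C(F)(F)F)c2)N(C)c2nc(Nc3ccc(S(N)(=O)=O)cc3)ncc21`: compound 2 gives 2710 nM

For the measured compounds named here, compound 2 carries the highest of the two numbers; its only neighbour is compound 1, and the step of a 5.7-fold higher number from compound 1 to compound 2 (0.75 log units; beyond the scatter) places the two apart by more than the scatter. The next compound, compound 3 `CN1C(=O)C(c2c(F)cccc2F)N(C)c2nc(Nc3ccc(S(N)(=O)=O)cc3)ncc21`, changes the same position once more: 2,6-difluorophenyl in place of 3-(trifluoromethyl)phenyl on a saturated ring carbon.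

Going by the values given here, only one measured step touches this position, a 5.7-fold higher number from compound 1 to compound 2 (0.75 log units; beyond the scatter), and it compares an aryl with an alkyl group, not one aryl with another. It shows that the aryl-bearing compound 2 sits well above compound 1, but says nothing about how one aryl group compares with another. An aryl-to-aryl exchange is therefore expected to move the number by less than that step, with no firm direction; a modest lowering is taken as the central expectation. Compound 3 is estimated at 1500 nM, range 400 nM to 5000 nM, which means an expected step of a 1.8-fold lower number from compound 2 to compound 3 (0.26 log units; within the scatter).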

Compound 3, half-maximal inhibitory concentration: 42 nM
For compound 3 the middle estimate is 36-fold (1.55 log units) above the measured one, outside the stated range (below it).
By their numbers in this assay, from the lowest: compound 3; then compound 1; then compound 2.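

The aryl-for-aryl exchange gives a 65-fold lower number from compound 2 to compound 3 (1.81 log units; beyond the scatter) in this assay and shows that the number at this saturated ring carbon depends strongly on which aryl group is present, not merely on an aryl group being there. Replacing ethyl with 2,6-difluorophenyl gives an 11-fold lower number from compound 1 to compound 3 (1.06 log units; beyond the scatter) and so reverses the direction seen with 3-(trifluoromethyl)phenyl: an aryl group in this place need not raise the number. No measurement is available that explains the difference between these two aryl groups.

The two aryl groups differ in both their substituents and where those substituents sit, so the contribution of each remains unresolved. On these data alone, how a plain phenyl, a 2-fluorophenyl or a 2,6-dichlorophenyl would compare also remains open, as does the effect of an amine or a carboxylic acid on the ring.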